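Cyclohexyl in Place of Pentan-3-yl on the Chain Carbon

This account rests on a few compounds, and the source may have more. Where it says the series, first, only, none or still open, it means among the compounds named here.

Measured compounds:
compound 1, `CCc1cccc2ccc(-c3ccc(C(/C=C4\OC(=O)NC4=O)(CC)CC)c(=O)[nH]3)cc12`: 17 nM
compound 2, `CCC(/C=C1\OC(=O)NC1=O)(CC)c1ccc(-c2ccc3cccc(F)c3c2)[nH]c1=O`: 13 nM
compound 3, `CCC(CC)C(/C=C1\OC(=O)NC1=O)c1ccc(-c2ccc3cccc(F)c3c2)[nH]c1=O`: 13 nM

In an assay on membranes from Chem-1 cells for displacement of a labelled ligand from prostaglandin E2 receptor EP3 subtype (Homo sapiens), read by scintillation counting, with a stated time of 2 h (on this read-out lower numbers stand for stronger inhibition and higher numbers for weaker inhibition), compound 3 gives 13 nM, level at the digits shown with the number of compound 2 and within the scatter of that of compound 1. Within the data shown here, the only measured step, a 1.3-fold lower number from compound 1 to compound 2 (0.12 log units; within the scatter), concerns the aromatic fluoro and ethyl and lies within the scatter. Among the measured compounds shown here, compound 4, `O=C1NC(=O)/C(=C/C(c2ccc(-c3ccc4cccc(F)c4c3)[nH]c2=O)C2CCCCC2)O1`, carries a (cyclohexyl in place of pentan-3-yl on a saturated chain carbon bound to an aromatic carbon and a double-bonded chain carbon); no measured step touches that chain carbon, so nothing in the data points to a change beyond the scatter. The expected step is a 1.2-fold higher number from compound 3 to compound 4 (0.06 log units; within the scatter), and compound 4 is estimated at 15 nM, with a range from 6 nM to 40 nM.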

Compound 4, inhibition constant: 4 nM
Estimate against measurement, compound 4: 3.8-fold (0.57 log units) above, outside the stated range (below it).
By their numbers in this assay, from the lowest: compound 4; then compounds 2, 3 and 1 (each within the scatter of the next).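

In this assay, among these compounds, the saturated chain carbon bound to an aromatic carbon and a double-bonded chain carbon responds to its substituent: cyclohexyl in place of pentan-3-yl gives a 3.3-fold lower number from compound 3 to compound 4 (0.51 log units; beyond the scatter) and so moves the number beyond the scatter, which the one earlier step, at an aromatic carbon, did not do. No evidence available here accounts for this difference.

The compounds shown leave open whether cyclopentyl, phenyl or piperidinyl on this carbon would match cyclohexyl. They also leave open whether cyclohexyl would give a similar step with ethyl in place of fluoro on the aromatic carbon.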